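Replacing the hydroxypyrrolidinyl group of compound 1 with a hydroxycyclopentylamino group

The source may report more compounds than this note shows. Statements on the series, on what has been measured and on what is new or still open speak of the compounds shown alone.

Compound 1 `COc1cc[nH]c1/C=C1\C(=O)Nc2ccc([N+](=O)[O-])c(N3CC[C@H](O)C3)c21` gives 104 nM in a functional assay on MDA-MB-435 cells (Homo sapiens) for antiproliferative activity, read by MTT assay, with a stated time of 5 days (a lower number here means a stronger inhibitor, a higher number a weaker inhibitor), the lowest of the two numbers in hand; its nearest neighbour is compound 2 `COc1cc[nH]c1/C=C1\C(=O)Nc2ccc([N+](=O)[O-])c(N[C@H]3CC[C@H](O)CC3)c21`, which gives 8550 nM. Compound 3 `COc1cc[nH]c1/C=C1\C(=O)Nc2ccc([N+](=O)[O-])c(N3CC[C@@H](N)C3)c21` is reported only as a limit, < 10 nM, in this assay (the limit of < 10 nM in this assay, at which 1 of the 3 values shown sits). Compound 4 `COc1cc[nH]c1/C=C1\C(=O)Nc2ccc([N+](=O)[O-])c(N[C@H]3CC[C@H](O)C3)c21` differs from compound 1 by (3-hydroxycyclopentyl)amino in place of 3-hydroxypyrrolidin-1-yl on an aromatic carbon. Going by the values given here, the step that bears on this change is the one from compound 1 to compound 2, in which a (4-hydroxycyclohexyl)amino group likewise replaced the 3-hydroxypyrrolidin-1-yl group and gave an 82-fold higher number from compound 1 to compound 2 (1.91 log units; beyond the scatter); the steps involving compound 3 keep the 3-hydroxypyrrolidin-1-yl group and say less. A large rise in this assay is therefore expected for compound 4, a 24-fold higher number from compound 1 to compound 4 (1.38 log units; beyond the scatter). Compound 4 is estimated at 2500 nM, between 500 nM and 10000 nM.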

Compound 4, half-maximal inhibitory concentration: 1000 nM
The estimate for compound 4 lay 2.5-fold (0.40 log units) above the measured number; low and high end bracket the measured number.
By their numbers in this assay, from the lowest: compound 1; then compound 4; then compound 2. At a limit, below all of these: compound 3.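

In this assay, the (3-hydroxycyclopentyl)amino group on this aromatic carbon still gives a weaker result than 3-hydroxypyrrolidin-1-yl, with a 9.6-fold higher number from compound 1 to compound 4 (0.98 log units; beyond the scatter). Ring size on the nitrogen also counts, since 3-hydroxycyclopentyl in place of 4-hydroxycyclohexyl gives an 8.6-fold lower number from compound 2 to compound 4 (0.93 log units; beyond the scatter). Read against a limit, 3-aminopyrrolidin-1-yl stands clear of the new group, with an at least 100-fold higher number from compound 3 to compound 4 (2.00 log units; beyond the scatter): the limit of < 10 nM in this assay, at which 1 of the 4 values shown sits.

The compounds shown leave open whether an amine in place of the hydroxyl on the cyclopentyl ring would lower the number, as it does on the pyrrolidine ring. Going by these compounds, how an open chain such as 2-hydroxyethylamino would compare also remains unknown.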